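Prostacyclin synthase series: nitrophenoxy to fluorocyanobenzyl exchange

The source may report more compounds than this note shows. Statements on the series, on what has been measured and on what is new or still open speak of the compounds shown alone.

compound 1 `CC(C)(Oc1ccccc1Br)C1OCC(C/C=C\CCC(=O)O)C(c2cccnc2)O1`: 7000 nM
compound 2 `CC(C)(Oc1ccccc1[N+](=O)[O-])C1OCC(C/C=C\CCC(=O)O)C(c2cccnc2)O1`: < 1000 nM

In an assay for inhibition of prostacyclin synthase (Homo sapiens), using microsomes (a higher number here means a weaker inhibitor, a lower number a stronger inhibitor), compound 1 gives 7000 nM. Compound 2 reaches only a limit, < 1000 nM (the limit of < 1000 nM in this assay, at which 1 of the 2 values shown sits). Going by the values given here, the one measured step, an at least 7.0-fold lower number from compound 1 to compound 2 (0.84 log units; beyond the scatter), changes the substituent on the aromatic ring but not its link to the core. Compound 3 `CC(C)(Cc1ccc(F)cc1C#N)C1OCC(C/C=C\CCC(=O)O)C(c2cccnc2)O1` carries a group of 10 heavy atoms (8 carbon, 1 nitrogen, 1 fluorine; one six-membered aromatic ring of carbon only) in place of a group of 10 heavy atoms (6 carbon, 1 nitrogen, 3 oxygen; one six-membered aromatic ring of carbon only), on a saturated chain carbon bound to two saturated chain carbons and a saturated ring carbon: the ether oxygen is lost, and a nitrile and a fluorine appear on the new ring. Among the compounds with values here, no measured step covers such an exchange, and compound 2 is known only as a limit, so the step of an at least 1.5-fold higher number from compound 2 to compound 3 (0.17 log units; that floor lies within the scatter) is expected to be modest at most, in either direction. Compound 3 is therefore estimated at 1500 nM (range 300 nM to 8000 nM).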

Compound 3, half-maximal inhibitory concentration: 7000 nM
Compound 3: the middle estimate sits 4.7-fold (0.67 log units) below what was measured; low and high end bracket the measured number.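

At this saturated chain carbon, the exchange of 2-nitrophenoxy for the fluorine- and nitrile-bearing group gives an at least 7.0-fold higher number from compound 2 to compound 3 (0.84 log units; beyond the scatter) and shows that the position responds to a change of the whole group as well as of a ring substituent. Set against the bromophenoxy group, the same group gives no change at the digits printed from compound 1 to compound 3 (within the scatter) and leaves the loss of the ether oxygen tied to changes in the ring substituents. Compound 2 stands only as a limit: the limit of < 1000 nM in this assay, at which 1 of the 3 values shown sits.

From the compounds shown here alone, how far the true value of compound 2 lies from that limit stays open. Also open, going by these compounds, is whether an amine on the phenoxy ring would match the nitro group.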